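A few compounds are considered here, and "the series" means these few. Any claim that something is new, unique, unknown or untested is made for them only; others in the source may bear on it.

Measured so far:
compound 1 `O=C1COCCN1c1ccc(/N=C\c2c[nH]c3ccccc23)cc1`, 97.8%
compound 2 `Cc1ccc(S(=O)(=O)n2cc(/C=N\c3ccc(N4CCOCC4=O)cc3)c3ccccc32)cc1`, 57.8%

Compound 2 stands lowest of the two numbers in an ADME assay on BV-2 cells (Mus musculus) for cytotoxicity, read by MTT assay, with a stated time of 48 h, tested at 80 uM; a lower number here means a stronger effect, a higher number a weaker effect of the compound at the concentration tested; its nearest neighbour is compound 1, which lies higher by a margin beyond the scatter. For the measured compounds named here, the only measured step, a number 40 percentage points lower from compound 1 to compound 2 (beyond the scatter), was large and came from a (4-methylphenyl)sulfonyl in place of hydrogen on an aromatic nitrogen. Compound 3 `O=C1COCCN1c1ccc(/N=C\c2cn(C(=O)c3ccccc3)c3ccccc23)cc1` differs from compound 2 in that same place: benzoyl in place of (4-methylphenyl)sulfonyl on an aromatic nitrogen. That step bears on it only loosely, since it compares a substituted aromatic nitrogen with an unsubstituted one, whereas here one large group replaces another of similar size. A step smaller than the measured one, probably back towards compound 1, is therefore expected, though the data give no firm direction. Compound 3 is estimated at 70%, within 48% to 92%, which is expected to mean a number 12.2 percentage points higher from compound 2 to compound 3 (beyond the scatter).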

Compound 3, a percentage reported as activity, at one concentration (the size of the read-out at that concentration, not a potency): 58.4%
Compound 3: middle estimate off by 11.6 percentage points, on the high side; measured number inside the range.
By their numbers in this assay, from the lowest: compounds 2 and 3 (each within the scatter of the next); then compound 1.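

In this assay, benzoyl in place of (4-methylphenyl)sulfonyl on the aromatic nitrogen gives a number 0.6 percentage points higher from compound 2 to compound 3 (within the scatter), so these two groups cannot be told apart at this position. Benzoyl in place of hydrogen on the same nitrogen gives a number 39.4 percentage points lower from compound 1 to compound 3 (beyond the scatter), which shows that the large step first seen with the sulfonyl group is not confined to that group. Nothing available bears on why the two groups read alike.

The compounds shown leave open whether the step needs the six-membered aromatic ring that both groups carry, which a methyl or an acetyl group on the same nitrogen would test. They also leave open whether the read-out would hold with a chain ending in an amine or a carboxylic acid at this nitrogen.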